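The compounds below may be only part of what the source reports. "The series", "measured", "known", "first", "only" and "open" are said of these compounds alone.

In a functional assay on MDA-MB-468 cells (Homo sapiens) for antiproliferative activity, read by sulforhodamine B assay, with a stated time of 48 h (a lower number here means a stronger inhibitor of growth, a higher number a weaker inhibitor of growth), two compounds have been measured:

Compound 1 (`O=C(NCCCNc1cc(-c2cn(-c3ccccc3)nc2-c2cccc(O)c2)ccn1)Nc1ccc(F)cc1`) gives 4660 nM
Compound 2 (`O=C(NCCCNc1cc(-c2cn(-c3ccccc3)nc2-c2cccc(O)c2)ccn1)Nc1cccc(C(F)(F)F)c1`) gives 6160 nM

Compound 1 has only compound 2 to stand against, and the two cannot be separated (a 1.3-fold higher number from compound 1 to compound 2 (0.12 log units; within the scatter)). It therefore holds no distinct rank in this assay for now.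

Compound 3 (`COc1cccc(-c2nn(-c3ccccc3)cc2-c2ccnc(NCCCNC(=O)Nc3ccc(F)cc3)c2)c1`) departs from compound 1 at a single place (methyl in place of hydrogen on an oxygen on an aromatic ring). This is methyl in place of hydrogen on an oxygen on an aromatic ring, which turns 3-hydroxyphenyl into 3-methoxyphenyl.

Among the measured compounds shown here, the one measured step (a 1.3-fold higher number from compound 1 to compound 2 (0.12 log units; within the scatter)) changes the group on an amide-type nitrogen, not this oxygen, so it bears on the new change only indirectly. For the measured compounds named here, no measured compound shows what happens at the oxygen, and the data give neither size nor direction for it. The starting point is therefore compound 1 (4660 nM), and no step beyond the scatter is expected, though with a margin wider than the scatter.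

The expected step is small (a 1.2-fold higher number from compound 1 to compound 3 (0.07 log units; within the scatter)). The estimate for compound 3 is 5500 nM, with an expected range from 2500 nM to 12000 nM, and the measurement itself is still to come.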

Compound 3, concentration for total growth inhibition: 13000 nM
Compound 3: middle estimate off by 2.4-fold (0.37 log units), on the low side; measured number outside the range, above it.
By their numbers in this assay, from the lowest: compounds 1 and 2 (each within the scatter of the next); then compound 3.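

In this assay, among the compounds shown here, the change at the oxygen gives the first step that lies beyond the scatter: a 2.8-fold higher number from compound 1 to compound 3 (0.45 log units; beyond the scatter), whereas the change on the amide-type nitrogen remains within it, at a 1.3-fold higher number from compound 1 to compound 2 (0.12 log units; within the scatter). This shows that the oxygen on the aromatic ring is a place where a single added methyl, turning 3-hydroxyphenyl into 3-methoxyphenyl, modestly weakens growth inhibition, which the earlier pair could not reveal. Nothing available accounts for the size or direction of this step.

This one change removes the hydrogen on the oxygen and adds a methyl at the same time, so the compounds shown do not separate these two events, and an amine or a fluorine in place of the hydroxy group, or an ethoxy group in place of the methoxy group, would be needed to tell them apart. Going by these compounds, it also remains open whether the same step would appear with 3-(trifluoromethyl)phenyl in place of 4-fluorophenyl on the amide-type nitrogen.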